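A swap of pyridin-3-yl for 1,3-benzoxazol-5-yl

The source may report more compounds than this note shows. Statements on the series, on what has been measured and on what is new or still open speak of the compounds shown alone.

- compound 1 `Nc1ccc(S(=O)(=O)N2CCN(c3ncc(C(O)(C(F)(F)F)C(F)(F)F)cc3C#CC3CC3)CC2)cn1`: < 14 mL.min-1.g-1, a limit of the assay
- compound 2 `Nc1ccc(S(=O)(=O)N2CCN(c3ncc(C(O)(C(F)(F)F)C(F)(F)F)cc3-c3ccccc3O)CC2)cn1`: 22 mL.min-1.g-1
- compound 3 `Nc1ccc(S(=O)(=O)N2CCN(c3ncc(C(O)(C(F)(F)F)C(F)(F)F)cc3-c3cccnc3)CC2)cn1`: 17 mL.min-1.g-1

These values come from an ADME assay (liver) for metabolic stability, with Liver microsome (Homo sapiens) as the target, using microsomes and NADPH, with a stated time of 30 min, tested at 1 uM; on this read-out higher numbers stand for fast clearance and lower numbers for slow clearance. Among the measured compounds shown here, compound 3 has a measured value within the scatter of its only numerical neighbour, as a 1.3-fold lower number from compound 2 to compound 3 (0.11 log units; within the scatter) shows. Compound 1 is known only through its limit, < 14 mL.min-1.g-1.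

Compound 4 `Nc1ccc(S(=O)(=O)N2CCN(c3ncc(C(O)(C(F)(F)F)C(F)(F)F)cc3-c3ccc4ocnc4c3)CC2)cn1` carries 1,3-benzoxazol-5-yl in place of pyridin-3-yl on an aromatic carbon. For the measured compounds named here, three measured steps concern that same carbon. They are an at least 1.5-fold higher number from compound 1 to compound 2 (0.19 log units; that floor lies within the scatter), an at least 1.2-fold higher number from compound 1 to compound 3 (0.08 log units; that floor lies within the scatter) and a 1.3-fold lower number from compound 2 to compound 3 (0.11 log units; within the scatter). The first two are only floors, and none of the three goes beyond the scatter. A step within the scatter, with no firm direction, is therefore expected in this assay. The estimated step is a 1.1-fold higher number from compound 3 to compound 4 (0.05 log units; within the scatter). Compound 4 is expected at 19 mL.min-1.g-1, with an estimated range of 12 mL.min-1.g-1 to 32 mL.min-1.g-1.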

Compound 4, intrinsic clearance in microsomes: < 14 mL.min-1.g-1
Compound 4: only a limit was reported; the forecaster's own chance of this, stated with the estimate: 20%; middle value at least 1.3-fold (0.13 log units) away from the limit.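

In this assay, compound 4 gives < 14 mL.min-1.g-1, which is a limit of the assay. The two readable steps are an at least 1.2-fold lower number from compound 3 to compound 4 (0.08 log units; that floor lies within the scatter) and an at least 1.5-fold lower number from compound 2 to compound 4 (0.19 log units; that floor lies within the scatter); both are floors, so larger steps are not excluded, and this carbon is now seen to carry 1,3-benzoxazol-5-yl, with its second aromatic ring, without the number rising over that of compound 3. The step between compound 1 and compound 4 cannot be read, and the two cannot be ordered because both sit at the same limit: the limit of < 14 mL.min-1.g-1 in this assay, at which 2 of the 4 values shown sit.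

On these data alone, how far the true values of compound 1 and compound 4 lie from that limit remains unknown. Also open, as far as these compounds go, is how this read-out responds when the aromatic group on this carbon carries an amine or a carboxylic acid.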